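The compounds below may be only part of what the source reports. "The series", "measured", "known", "first", "only" and "open" are said of these compounds alone.

Measured so far:
Compound 1, `COc1cc(/C=C/C(=O)/C=C/c2cc(OC)c(OC)c(OC)c2)ccc1OCc1cn(CCOc2cc(=O)oc3ccccc23)nn1`, in a functional assay on COLO 205 cells (Homo sapiens) for inhibition, read by sulforhodamine B assay, with a stated time of 48 h, tested at 50 uM (a higher number here means more inhibition of growth at the concentration tested, a lower number less inhibition of growth), compound 1 gives 86%.
Compound 2, `COc1cc(/C=C/C(=O)/C=C/c2ccccc2)ccc1OCc1cn(CCOc2cc(=O)oc3ccccc23)nn1`, compound 2 gives 54%.
Compound 3, `COc1cc(/C=C/C(=O)/C=C/c2ccccc2)ccc1OCc1cn(CCCOc2cc(=O)oc3ccccc23)nn1`, compound 3 gives 43%.

Compound 4, `COc1cc(/C=C/C(=O)/C=C/c2cc(OC)c(OC)c(OC)c2)ccc1OCc1cn(CCCOc2cc(=O)oc3ccccc23)nn1`, has not yet been measured. It comes from compound 3 by one change: 3,4,5-trimethoxyphenyl in place of phenyl on a double-bonded chain carbon bound to a double-bonded chain carbon. The same change links compound 2 to compound 1: 3,4,5-trimethoxyphenyl in place of phenyl on a double-bonded chain carbon bound to a double-bonded chain carbon. There it made a large step, a number 32 percentage points higher from compound 2 to compound 1 (beyond the scatter). The cores of compound 2 and compound 3 differ, but how they differ is not broken down here; their values show compound 3 lower than compound 2. For the measured compounds named here, since the change to compound 4 is made on the same place and in the same words as the change to compound 1, a step of similar size is expected from compound 3 to compound 4 in this assay, resting on the one step that has been seen, a number 32 percentage points higher from compound 2 to compound 1 (beyond the scatter). The expected step is a number 30 percentage points higher from compound 3 to compound 4 (beyond the scatter). Compound 4 is therefore estimated at 73%, with a likely range from 55% to 90%.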

Compound 4, percent growth inhibition at one concentration: 74%
For compound 4 the middle estimate is 1 percentage points below the measured one; measured number inside the range.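

In this assay, 3,4,5-trimethoxyphenyl in place of phenyl gives a number 31 percentage points higher from compound 3 to compound 4 (beyond the scatter), so on these two cores the change carries over with its size intact, as setting the two steps side by side shows: the same change on two cores in this assay, a number 32 percentage points higher (beyond the scatter) from compound 2 to compound 1 and a number 31 percentage points higher (beyond the scatter) from compound 3 to compound 4, 1 percentage points apart, within the scatter of two such steps

For the compounds shown here, this rests on only two pairs of compounds, tested in one cell line at one concentration, so it does not show that the step would hold on any further core. Nor does it explain why the change raises growth inhibition; the numbers show only that it does so to a matching extent on both cores.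

Only phenyl and 3,4,5-trimethoxyphenyl appear at this place among the compounds shown, so it remains open how a phenyl carrying a single methoxy group, an amine or a carboxylic acid would compare. On these data alone, it also remains open whether the step would survive on a core with a longer chain than those in compound 1 and compound 4.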